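One More Swap at an Aromatic Carbon

The source may hold more compounds than are shown below. What is called first, only, known or untested is meant among the compounds shown, and "the series" means these compounds.

Compound 1 (`CCCCNc1nc(N)nc2cc(OC)ccc12`) and compound 2 (`CCCCNc1nc(N)nc2cc(C(=O)N(C)C)ccc12`) share a core and carry different groups on one aromatic carbon. In an ADME assay on HEK293 cells (Homo sapiens) for cytotoxicity, with a stated time of 6 h (a lower number here means that less compound is tolerated, a higher number that more compound is tolerated), compound 1 gives > 18000 nM as a limit, not a number. Compound 2 gives > 18000 nM as a limit too, so its standing can be told only as a limit and not as an exact value. The next change leads to compound 3 (`CCCCNc1nc(N)nc2cc(CN(C)C)ccc12`), with (dimethylamino)methyl in place of dimethylcarbamoyl on that aromatic carbon ((dimethylamino)methyl in place of dimethylcarbamoyl on an aromatic carbon). Among the measured compounds shown here, the one measured step that bears on this change is a step that the two limits leave unreadable from compound 1 to compound 2 and it offers no size to carry over. Compound 2 sits at the limit of > 18000 nM in this assay, at which 2 of the 2 values shown sit, and so no step beyond the scatter is expected in this assay for the new change. The expected move is a step that the limit leaves unreadable from compound 2 to compound 3 and nothing larger is estimated. For compound 3 the estimated value is 20000 nM with an expected range of 10000 nM to 40000 nM and a report of only a limit is again likely.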

Compound 3, half-maximal cytotoxic concentration: > 18000 nM
Compound 3 was reported as a limit; the forecaster's own chance of this, stated with the estimate: 75%; the middle value does not contradict the limit.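

In this assay compound 3 gives > 18000 nM, which is a limit and not a number. The steps to compound 3 from compound 1 and from compound 2 therefore cannot be read, as all of them stand at the same limit: the limit of > 18000 nM in this assay, at which 3 of the 3 values shown sit. The compounds shown leave open how far each lies beyond that limit, and so whether swapping the group on this aromatic carbon changes the tolerated concentration at all.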